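The compounds below may be only part of what the source reports. "The series", "measured", "known", "first", "only" and "open" are said of these compounds alone.

Among the compounds with values here, compound 1 `CCCCCCCCOP(=O)(O)OCCSC(=S)N1CCCC1` gives 69000 nM in a functional assay on MDA-MB-231 cells (Homo sapiens) for inhibition, read by MTT assay, with stated times of 18 h and 4 h (a higher number here means a weaker inhibitor, a lower number a stronger inhibitor), the only plain number in the set. Compound 2 `CCCCCCCCCCCCCCCCOP(=O)(O)OCCSC(=S)N1CCN(C)CC1` returns only a limit of > 100000 nM in this assay; the limit of > 100000 nM in this assay, at which 1 of the 2 values shown sits, marks where that value sits. Compound 3 `CCCCCCCCOP(=O)(O)OCCSC(=S)N1CCCCCC1` remains to be measured. Against compound 1 it carries azepan-1-yl in place of pyrrolidin-1-yl on a thiocarbonyl carbon. Within the data shown here, no measured pair covers a change of this kind, so the step expected in this assay is a 1.3-fold lower number from compound 1 to compound 3 (0.10 log units; within the scatter), judged to lie within the usual scatter rather than beyond it. Compound 3 is accordingly estimated at 55000 nM, with a range from 25000 nM to 100000 nM.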

Compound 3, half-maximal inhibitory concentration: 27000 nM
Beside the measured number, compound 3's estimate is 2.0-fold (0.31 log units) above it; the range from low to high includes it.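

Within the data shown here, on the thiocarbonyl carbon, the ring is the first change that can be read in this assay: azepan-1-yl in place of pyrrolidin-1-yl gives a 2.6-fold lower number from compound 1 to compound 3 (0.41 log units; beyond the scatter), a modest step. This shows that the number responds to this ring, with the rest of the core of compound 1 unchanged. Nothing shown accounts for the step.

Still open, going by these compounds, is where piperidin-1-yl would stand relative to these two rings, and whether an open-chain diethylamino group would keep the step. On these data alone, whether the step holds with a dodecyl chain is also open.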